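Thioamide Aryl Swap: From Trifluoromethylphenyl to Pyridinyl

The compounds below may be only part of what the source reports. "The series", "measured", "known", "first", "only" and "open" are said of these compounds alone.

Measured so far in a functional assay on HL-60 cells (Homo sapiens) for antiproliferative activity, with a stated time of 24 h; a higher number here means a weaker inhibitor, a lower number a stronger inhibitor:
Compound 1, `NC(=O)c1c(NC(=O)c2ccccc2Cl)sc2c1CCN(Cc1ccccc1)C2`, gives 12000 nM.
Compound 2, `NC(=O)c1c(NC(=O)c2ccccc2Cl)sc2c1CCN(C(=S)Nc1ccccc1I)C2`, gives 4430 nM.
Compound 3, `NC(=O)c1c(NC(=O)c2ccccc2Cl)sc2c1CCN(C(=S)Nc1ccccc1C(F)(F)F)C2`, gives 10600 nM.

Compound 3 stands second highest of the three numbers. Its nearest neighbour is compound 1, whose number sits within the scatter of it, so the two cannot be ranked; compound 2 lies further off, with a step of a 2.4-fold higher number from compound 2 to compound 3 (0.38 log units; beyond the scatter) separating them.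

Compound 4, `NC(=O)c1c(NC(=O)c2ccccc2Cl)sc2c1CCN(C(=S)Nc1cccnc1)C2`, differs from compound 3 by pyridin-3-yl in place of 2-(trifluoromethyl)phenyl on an amide-type nitrogen.

Among the compounds with values here, two measured steps bear loosely on this. The step of a 2.4-fold higher number from compound 2 to compound 3 (0.38 log units; beyond the scatter) shows that swapping one group on the aromatic ring moves the number only modestly. The step of a 2.7-fold lower number from compound 1 to compound 2 (0.43 log units; beyond the scatter) shows that the whole amide-type nitrogen substituent can shift the number by a similar modest amount. Neither step replaces the aromatic ring itself with pyridin-3-yl, so the direction is open; a step of a 1.2-fold lower number from compound 3 to compound 4 (0.07 log units; within the scatter) that stays within the scatter is the expected outcome. Compound 4 is therefore estimated at 9000 nM in this assay, with a range from 3000 nM to 30000 nM.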

Compound 4, half-maximal inhibitory concentration: 33900 nM
Estimate against measurement, compound 4: 3.8-fold (0.58 log units) below; measured number outside the range, above it.
By their numbers in this assay, from the lowest: compound 2; then compounds 3 and 1 (each within the scatter of the next); then compound 4.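

In this assay, within the data shown here, the earlier compounds varied only a group carried on a carbon-only aromatic ring, whereas changing to pyridin-3-yl on this amide-type nitrogen gives a larger shift against the 2-iodophenyl compound (a 7.7-fold higher number from compound 2 to compound 4 (0.88 log units; beyond the scatter)) than against the 2-(trifluoromethyl)phenyl compound (a 3.2-fold higher number from compound 3 to compound 4 (0.50 log units; beyond the scatter)). Both steps go towards weaker inhibition, so this position responds to the identity of the aromatic ring as well as to its substituent. A thiocarbonyl-linked group also does not guarantee a gain over the benzyl group of compound 1 (a 2.8-fold higher number from compound 1 to compound 4 (0.45 log units; beyond the scatter)), and no measurement here explains these shifts.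

As far as these compounds go, each step changes the ring and removes its substituent at once, so their separate contributions remain open. An unsubstituted phenyl, or a pyridine ring bearing a methyl group, on the same nitrogen would help separate them.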